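Carbonyl substituent change from compound 2 to compound 3

The source may report more compounds than this note shows. Statements on the series, on what has been measured and on what is new or still open speak of the compounds shown alone.

Measured so far:
compound 1, `Cc1[nH]nc(N)c1-c1ccc(Cl)c(Cl)c1`: > 100000 nM
compound 2, `Cc1nn(C(=O)C2CC2)c(N)c1-c1ccc(Cl)c(Cl)c1`: > 100000 nM

In an assay on Sf9 cells for inhibition of inhibitor of nuclear factor kappa-B kinase subunit epsilon (Homo sapiens), read by ADP-Glo, with a stated time of 60 min (on this read-out lower numbers stand for stronger inhibition and higher numbers for weaker inhibition), compound 1 returns only a limit, > 100000 nM, with no number behind it. In this assay compound 2 likewise returns only a limit, > 100000 nM. Among the measured compounds shown here, compound 2 therefore stands at the top edge of what this assay reports, and the one other value shown sits at the same edge: the limit of > 100000 nM in this assay, at which 2 of the 2 values shown sit. For the measured compounds named here, no step between measured compounds exists to gauge the series, since both values are limits rather than numbers.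

Compound 3, `Cc1nn(C(=O)c2cccnc2)c(N)c1-c1ccc(Cl)c(Cl)c1`, is not yet measured. It differs from compound 2 in one place: pyridin-3-yl in place of cyclopropyl on a carbonyl carbon. The change sits on the carbonyl carbon whose other neighbour is the aromatic nitrogen.

Going by the values given here, with both known values at the limit, no measured step gives a direction. The expectation is that compound 3 also stays at or near the limit in this assay, so the expected step of a number no higher from compound 2 to compound 3 (the limit leaves the size open) is none beyond the scatter. Compound 3 is estimated at 100000 nM, within 20000 nM to 300000 nM.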

Compound 3, half-maximal inhibitory concentration: > 100000 nM
Compound 3 was reported as a limit; the forecaster's own chance of this, stated with the estimate: 75%; the middle value sits exactly at the limit.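

Compound 2 and compound 3 both return only limits in this assay, so no step can be read for pyridin-3-yl in place of cyclopropyl on the carbonyl carbon: the limit of > 100000 nM in this assay, at which 3 of the 3 values shown sit.

The compounds shown leave open whether any group on that carbonyl carbon gives a measured number in this assay rather than a limit.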